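The source may report more compounds than this note shows. Statements on the series, on what has been measured and on what is new or still open speak of the compounds shown alone.

Two compounds sharing one core have been examined so far. Within the data shown here, compound 1 `CC(C)(C)c1cc(NC(=O)Nc2ccc(Cl)cc2)n(-c2ccc(OC(F)(F)F)cc2)n1` carries a trifluoromethoxy group on the outer ring, and in an assay on isolated protein for inhibition of Ephrin type-A receptor 2 (Homo sapiens), read by thermal shift assay, tested at 10 uM (on this read-out higher numbers stand for stronger stabilisation of the target against heat and lower numbers for weaker stabilisation of the target), compound 1 gives 0.9 degrees C. Compound 2 `CC(C)(C)c1cc(NC(=O)Nc2ccc(Cl)cc2)n(-c2ccc(S(C)(=O)=O)cc2)n1` carries a methylsulfonyl group at the same place instead, and in this assay compound 2 gives 1.2 degrees C. The only step measured so far runs from one to the other: a number 0.30 degrees C higher from compound 1 to compound 2 (within the scatter). On the numbers shown, compound 2 and compound 1 therefore cannot be told apart, and neither shift is large.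

Compound 3 `CC(C)(C)c1cc(NC(=O)Nc2ccc(Cl)cc2)n(-c2ccc(N)cc2)n1` is the next compound, not yet measured. Compared with compound 2 the change is amino in place of methylsulfonyl on an aromatic carbon. Among the measured compounds shown here, the one measured step that bears on this swaps a group at the very same place and stayed within the scatter, so a change at that place has not so far moved the reading much. The step into compound 3 is therefore expected to be small as well, a number 0.20 degrees C lower from compound 2 to compound 3 (within the scatter), with no direction that can be trusted beyond the scatter. For compound 3 in this assay the estimate is 1 degrees C, in the range from 0 degrees C to 2 degrees C.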

Compound 3, shift of the target's melting temperature: 2 degrees C
Beside the measured number, compound 3's estimate is 1.0 degrees C below it, and the stated range covers the measured number.
By their numbers in this assay, from the lowest: compounds 1, 2 and 3 (each within the scatter of the next, the first and the last beyond it).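

In this assay, among these compounds, the change to amino gives a number 1.1 degrees C higher from compound 1 to compound 3 (beyond the scatter), the first step at this position, para to a large group, that stands clear of the scatter. This shows that the reading can respond to the group placed here, although the effect is modest. Among the compounds shown here, the other step into the same compound, a number 0.80 degrees C higher from compound 2 to compound 3 (within the scatter), stays within the scatter, so amino and methylsulfonyl cannot be ranked against each other, and only the pair with trifluoromethoxy separates; no measurement available here explains why the reading moves.

The compounds shown leave open whether the hydrogen-bond donor that amino brings matters, since a dimethylamino group, an acetamide or a hydroxyl at the same place would be needed to separate that feature from the small size of the group. They also leave open whether a larger shift can be reached at all, because a carboxylic acid or an aminomethyl group here, or any change elsewhere on the shared core, has no reading among these three compounds.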